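The source may report more compounds than this note shows. Statements on the series, on what has been measured and on what is new or still open speak of the compounds shown alone.

Measured compounds:
Compound 1, `Cc1cc(N2CC[C@@H](C)[C@@H](N(C)c3ncnc4[nH]ccc34)C2)n2nc(SCCc3ccccc3)nc2n1`: 6190 nM
Compound 2, `Cc1cc(N2CC[C@@H](C)[C@@H](N(C)c3ncnc4[nH]ccc34)C2)n2nc(SCc3ccc(Br)cc3)nc2n1`: 4020 nM
Compound 3, `Cc1cc(N2CC[C@@H](C)[C@@H](N(C)c3ncnc4[nH]ccc34)C2)n2nc(SCc3ccc([N+](=O)[O-])cc3)nc2n1`: 27000 nM

These three share one core and differ only in the group on a saturated chain carbon bound to a sulfur. In a functional assay on MGC-803 cells (Homo sapiens) for inhibition, read by MTT assay, with a stated time of 72 h (on this read-out lower numbers stand for stronger inhibition and higher numbers for weaker inhibition), compound 3 gives the highest of the three numbers, and compound 1 and compound 2 give numbers within the scatter of each other.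

Compound 4 is `Cc1cc(N2CC[C@@H](C)[C@@H](N(C)c3ncnc4[nH]ccc34)C2)n2nc(SCc3csc4ccc(Cl)cc34)nc2n1`. Its change from compound 3 is 5-chloro-1-benzothiophen-3-yl in place of 4-nitrophenyl on a saturated chain carbon bound to a sulfur. Within the data shown here, two measured steps bear on this. The step of a 6.7-fold higher number from compound 2 to compound 3 (0.83 log units; beyond the scatter) and the step of a 4.4-fold higher number from compound 1 to compound 3 (0.64 log units; beyond the scatter) both show that the arrival of the 4-nitrophenyl group went with a modest rise in the number. Taking that group out again and bringing in a ring system carrying chlorine, as compound 2 carries bromine, is expected to move the number back down by a similar modest amount. Compound 4 is therefore expected to give 5000 nM in this assay, with a likely range from 1500 nM to 16000 nM. This estimate means an expected step of a 5.4-fold lower number from compound 3 to compound 4 (0.73 log units; beyond the scatter).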

Compound 4, half-maximal inhibitory concentration: > 100000 nM
Compound 4 ended at the assay's limit; the forecaster's own chance of this, stated with the estimate: 5%; at least 20-fold (1.30 log units) between middle value and limit.
By their numbers in this assay, from the lowest: compounds 2 and 1 (each within the scatter of the next); then compound 3. At a limit, above all of these: compound 4.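

Compound 4 stands at a limit, not at a measured number, in this assay: the limit of > 100000 nM in this assay, at which 1 of the 4 values shown sits.

Until now, changing the group on a saturated chain carbon bound to a sulfur had produced modest steps at most, but 5-chloro-1-benzothiophen-3-yl gives an at least 3.7-fold higher number from compound 3 to compound 4 (0.56 log units; beyond the scatter). The gaps to the other two compounds are large, with an at least 24-fold higher number from compound 2 to compound 4 (1.39 log units; beyond the scatter) and an at least 16-fold higher number from compound 1 to compound 4 (1.20 log units; beyond the scatter). This position therefore does not accept every aromatic group, and carrying a halogen, as compound 2 and compound 4 both do, did not keep the number low.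

Compound 4 brings in a second ring, chlorine and a ring sulfur together, so the compounds shown cannot say which of these goes with the loss. A plain 4-chlorophenyl or unsubstituted 1-benzothiophen-3-yl group would help separate them, while an amine or carboxylic acid on the phenyl ring remains an open question.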